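Anilide variation on the shared core: cytotoxicity notes

The source may report more compounds than this note shows. Statements on the series, on what has been measured and on what is new or still open speak of the compounds shown alone.

In an ADME assay on MT4 cells (Homo sapiens) for cytotoxicity, read by MTT assay, with a stated time of 5 days (a lower number here means that less compound is tolerated, a higher number that more compound is tolerated), compound 3 `Cc1cccc(NC(=O)CSc2snnc2-c2ccc(Br)cc2Br)c1C` gives 241000 nM, the highest of the two numbers available. Compound 2 `O=C(CSc1snnc1-c1ccc(Br)cc1Br)Nc1ccccc1` gives 24800 nM in this assay, so that a 9.7-fold higher number from compound 2 to compound 3 (0.99 log units; beyond the scatter). Compound 1 `Cc1cccc(C)c1NC(=O)CSc1snnc1-c1ccc(Br)cc1Br` gives >= 198000 nM, which is a limit of this assay and not a number. Compound 4 `O=C(CSc1snnc1-c1ccc(Br)cc1Br)Nc1ccc(Cl)cc1` carries 4-chlorophenyl in place of 2,3-dimethylphenyl on an amide-type nitrogen. Among the measured compounds shown here, two measured steps bear on this: a 9.7-fold higher number from compound 2 to compound 3 (0.99 log units; beyond the scatter) and an at least 7.9-fold lower number from compound 1 to compound 2 (0.90 log units; beyond the scatter). In both, the phenyl without methyls sits at the lower number. Compound 4 likewise lacks both methyls, so a modest move toward a lower number is expected, and the expected step is a 4.8-fold lower number from compound 3 to compound 4 (0.68 log units; beyond the scatter). Compound 4 is therefore estimated at 50000 nM, with a range from 15000 nM to 180000 nM.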

Compound 4, half-maximal cytotoxic concentration: 23300 nM
Compound 4: the middle estimate sits 2.1-fold (0.33 log units) above what was measured, within the range that was stated.
By their numbers in this assay, from the lowest: compounds 4 and 2 (each within the scatter of the next); then compound 3.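

In this assay, chloro in place of hydrogen on an aromatic carbon gives a 1.1-fold lower number from compound 2 to compound 4 (0.03 log units; within the scatter), so on the amide-type nitrogen 4-chlorophenyl sits level with plain phenyl. Against the two dimethylphenyl compounds, 4-chlorophenyl gives a 10-fold lower number from compound 3 to compound 4 (1.01 log units; beyond the scatter) and an at least 8.4-fold lower number from compound 1 to compound 4 (0.92 log units; beyond the scatter), so a chlorine does not take the place of the methyl pair in this read-out. Compound 1 carries a limit and not a number: the limit of >= 198000 nM in this assay, at which 1 of the 4 values shown sits.

Going by these compounds, whether a single methyl on the phenyl already moves the number stays open. So does the reading for an amine or a carboxylic acid on that ring.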